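Removing a Chloro Group from a Weak Growth Inhibitor

This account rests on a few compounds, and the source may have more. Where it says the series, first, only, none or still open, it means among the compounds named here.

Compound 3 `CN(c1cccc2c1CN(c1nc(Nc3ccc(Cl)c(C(F)(F)F)c3)ncc1C(F)(F)F)C2)S(C)(=O)=O` is the starting point. In a functional assay on U-87MG ATCC cells for antiproliferative activity against U-87 MG (Homo sapiens), read by spectrophotometry, with a stated time of 2 days (a higher number here means a weaker inhibitor of growth, a lower number a stronger inhibitor of growth), compound 3 gives only a limit, > 30000 nM, not a number. Two close relatives have numbers: compound 1 `CN(c1cccc2c1CN(c1nc(Nc3cc(C(F)(F)F)cc(C(F)(F)F)c3)ncc1C(F)(F)F)C2)S(C)(=O)=O` gives 16800 nM and compound 2 `Cc1cc(Cl)ccc1Nc1ncc(C(F)(F)F)c(N2Cc3cccc(N(C)S(C)(=O)=O)c3C2)n1` gives 28300 nM. Among the compounds with values here, the one step measured between neighbours, an at least 1.0-fold higher number from compound 2 to compound 3 (0.02 log units; that floor lies within the scatter), lies within the scatter. One of the three measured values sits at the limit of > 30000 nM in this assay, at which 1 of the 3 values shown sits. Compound 4 `CN(c1cccc2c1CN(c1nc(Nc3cccc(C(F)(F)F)c3)ncc1C(F)(F)F)C2)S(C)(=O)=O` is not yet measured; it differs from compound 3 by hydrogen in place of chloro on an aromatic carbon. Within the data shown here, no measured step removes a chloro group, so none of the measured pairs speaks directly to this change, and all three measured compounds are weak inhibitors of growth. The expected step is an at least 1.2-fold lower number from compound 3 to compound 4 (0.07 log units; that floor lies within the scatter), no more than the scatter. For compound 4 the estimate is 25000 nM, within 8000 nM to 60000 nM.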

Compound 4, concentration for 50% growth inhibition: > 30000 nM
Compound 4: a limit, no number; the forecaster's own chance of this, stated with the estimate: 45%; at least 1.2-fold (0.07 log units) between middle value and limit.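

In this assay, compound 3 and compound 4 each give only a limit, so the step for hydrogen in place of chloro cannot be read: the limit of > 30000 nM in this assay, at which 2 of the 4 values shown sit. Compound 4 shows an at least 1.0-fold higher number from compound 2 to compound 4 (0.02 log units; that floor lies within the scatter) and an at least 1.7-fold higher number from compound 1 to compound 4 (0.25 log units; that floor lies within the scatter). Taking off the chloro group therefore brings no readable gain in growth inhibition at this position.

Still open, from the compounds shown here alone, is whether an amine or a carboxylic acid at this position would give a number rather than a limit. Also open, going by these compounds, is how far past the limit compound 3 and compound 4 really lie.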